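Benzyl replacing chlorophenyl on the triazole nitrogen

The compounds below may be only part of what the source reports. "The series", "measured", "known", "first", "only" and "open" are said of these compounds alone.

Compound 1 `CCCCCc1ccc(C#Cc2c(-c3ccc(CCCCC)cc3)oc3nc(=O)n(Cc4cn(-c5ccccc5F)nn4)cc23)cc1` — 7340 nM
Compound 2 `CCCCCc1ccc(C#Cc2c(-c3ccc(CCCCC)cc3)oc3nc(=O)n(Cc4cn(-c5ccc(Cl)cc5)nn4)cc23)cc1` — > 100000 nM

In an ADME assay on WI-38 cells (Homo sapiens) for antiproliferative activity, read by MTT assay, with a stated time of 72 h (a lower number here means a stronger inhibitor, a higher number a weaker inhibitor), compound 1 gives 7340 nM. Compound 2 gives only a limit, > 100000 nM. Among the compounds with values here, the one measured step, an at least 13-fold higher number from compound 1 to compound 2 (1.13 log units; beyond the scatter), is large, and compound 2 sits at the limit of > 100000 nM in this assay, at which 1 of the 2 values shown sits, so its true position is open. Compound 3 `CCCCCc1ccc(C#Cc2c(-c3ccc(CCCCC)cc3)oc3nc(=O)n(Cc4cn(Cc5ccccc5)nn4)cc23)cc1` carries benzyl in place of 4-chlorophenyl on an aromatic nitrogen. Within the data shown here, no measured step covers this exchange; the first step shows only that the group on this nitrogen matters. A move back toward the number of compound 1 is expected, uncertainly: compound 3 is estimated at 40000 nM, between 8000 nM and 150000 nM, meaning an at least 2.5-fold lower number from compound 2 to compound 3 (0.39 log units; beyond the scatter).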

Compound 3, half-maximal inhibitory concentration: 2650 nM
The estimate for compound 3 lay 15-fold (1.18 log units) above the measured number; the whole stated range lies above it.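

In this assay, benzyl on this aromatic nitrogen gives an at least 37-fold lower number from compound 2 to compound 3 (1.57 log units; beyond the scatter), and also a 2.8-fold lower number from compound 1 to compound 3 (0.44 log units; beyond the scatter). Compound 2 stands at a limit, not at a number: the limit of > 100000 nM in this assay, at which 1 of the 3 values shown sits. Compound 3 therefore has the lowest number of the three, so a phenyl ring set directly on this nitrogen is not needed for a low number here.

Open, going by these compounds, is what a longer chain such as phenethyl, or an amine on this nitrogen, would do. Also open, on these data alone, is how a chlorine on the benzyl ring would act, and whether the halogen or its place separates 2-fluorophenyl from 4-chlorophenyl.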